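A few compounds are considered here, and "the series" means these few. Any claim that something is new, unique, unknown or untested is made for them only; others in the source may bear on it.

In an assay on isolated protein for agonist activity at Free fatty acid receptor 1 (Homo sapiens) (a higher number here means that more compound is needed for the effect, a lower number that less compound is needed), compound 1, `CC#CC(CC(=O)O)c1ccc(OCc2ccn3cc(-c4ccc(C5CCCCC5)cc4)nc3c2)cc1`, gives 559 nM. Compound 2, `CC#CC(CC(=O)O)c1ccc(OCc2ccc3nc(-c4cccc(C)c4)cn3c2)cc1`, gives 1050 nM in this assay. Compound 1 has the lowest of the two numbers, but the gap to compound 2 is within the usual scatter, so the two cannot be told apart on these data.

Compound 3, `CC#CC(CC(=O)O)c1ccc(OCc2ccn3cc(-c4ccc(F)cc4)nc3c2)cc1`, differs from compound 1 in one place: fluoro in place of cyclohexyl on an aromatic carbon. The change sits on an aromatic carbon of a six-membered aromatic ring of carbon only, para to a large group; cut one bond further out it reads 4-cyclohexylphenyl to 4-fluorophenyl.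

For the measured compounds named here, no measured pair in this set shows this change, so no step size is known from it. The expectation for compound 3 is a rise in this assay, a step of a 4.5-fold higher number from compound 1 to compound 3 (0.65 log units; beyond the scatter), that is, more compound needed. Compound 3 is estimated at 2500 nM, with a range from 800 nM to 8000 nM.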

Compound 3, half-maximal effective concentration: 783 nM
Compound 3: the middle estimate sits 3.2-fold (0.50 log units) above what was measured; the measured number lies below the stated range.
By their numbers in this assay, from the lowest: compounds 1, 3 and 2 (each within the scatter of the next).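

In this assay the exchange of cyclohexyl for fluoro on the aromatic carbon gives a 1.4-fold higher number from compound 1 to compound 3 (0.15 log units; within the scatter) and so leaves the two compounds indistinguishable. This position therefore accepts the change from 4-cyclohexylphenyl to 4-fluorophenyl, with six heavy atoms and a non-aromatic ring leaving and a single fluorine entering, without a step beyond the scatter. Nothing measured here bears on why the two compounds read alike.

The compounds shown leave open whether an amine, a carboxylic acid or a longer alkyl chain at this position would also stay within the scatter of compound 1. They also leave open whether the exchange of cyclohexyl for fluoro would give a similar step on a different core, such as that of compound 2.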